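The source may report more compounds than this note shows. Statements on the series, on what has been measured and on what is new or still open speak of the compounds shown alone.

Compound 1 `CS(=O)(=O)NC1CCC(CN2CCN(c3cc(=O)c4cc(C(F)(F)F)cc([N+](=O)[O-])c4s3)CC2)CC1`: 48.5 ug/mL
Compound 2 `O=C(OC1CCC(CN2CCN(c3cc(=O)c4cc(C(F)(F)F)cc([N+](=O)[O-])c4s3)CC2)CC1)c1ccncc1`: > 64 ug/mL
Compound 3 `Cc1ccc(C(=O)OC2CCC(CN3CCN(c4cc(=O)c5cc(C(F)(F)F)cc([N+](=O)[O-])c5s4)CC3)CC2)cc1`: > 64 ug/mL

In an ADME assay on Vero cells (Chlorocebus sabaeus) for cytotoxicity, read by MTT assay, with a stated time of 48 h (on this read-out lower numbers stand for stronger inhibition and higher numbers for weaker inhibition), compound 1 gives 48.5 ug/mL. For compound 2 the assay reports only a limit, > 64 ug/mL. For compound 3 likewise only a limit is reported, > 64 ug/mL, so compound 3 stands at the limit of > 64 ug/mL in this assay, at which 2 of the 3 values shown sit, rather than at a number. Compound 4 `CC(=O)NC1CCC(CN2CCN(c3cc(=O)c4cc(C(F)(F)F)cc([N+](=O)[O-])c4s3)CC2)CC1` differs from compound 3 in one place: acetamido in place of ((4-methylphenyl)carbonyl)oxy on a saturated ring carbon. Going by the values given here, the steps that bear on this change are an at least 1.3-fold higher number from compound 1 to compound 3 (0.12 log units; that floor lies within the scatter) and an at least 1.3-fold higher number from compound 1 to compound 2 (0.12 log units; that floor lies within the scatter); both run from the compound with a hydrogen-bond donor at that ring carbon to an ester without one, and both reach only a floor that lies within the scatter. Compound 4 again carries a group with one hydrogen-bond donor at that carbon, as compound 1 does, so compound 4 is expected to fall back near compound 1, which means an at least 1.2-fold lower number from compound 3 to compound 4 (0.09 log units; that floor lies within the scatter) as an expected step, with a real chance that the assay again reports only the limit. Compound 4 is therefore estimated at 52 ug/mL, with a range from 26 ug/mL to 110 ug/mL.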

Compound 4, half-maximal inhibitory concentration: > 64 ug/mL
Compound 4: only a limit was reported; the forecaster's own chance of this, stated with the estimate: 40%; at least 1.2-fold (0.09 log units) between middle value and limit.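

In this assay compound 4 is reported only as a limit, > 64 ug/mL, even though acetamido carries a hydrogen-bond donor, so a reading at that limit is no longer confined to the two esters. Acetyl in place of methylsulfonyl on the amine nitrogen gives an at least 1.3-fold higher number from compound 1 to compound 4 (0.12 log units; that floor lies within the scatter), so these two groups are not told apart, and compound 1 remains the only compound with an actual number. The steps to compound 4 from compound 2 and from compound 3 cannot be read, with limits at both ends, and the set now gathers at a single reading: the limit of > 64 ug/mL in this assay, at which 3 of the 4 values shown sit.

Going by these compounds, how far compound 2, compound 3 and compound 4 lie beyond that limit, and whether they differ at all, stays open. Also open, on these data alone, is what a free amine or a carboxylic acid on that saturated ring carbon would give in this assay.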